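A few compounds are considered here, and "the series" means these few. Any claim that something is new, unique, unknown or untested is made for them only; others in the source may bear on it.

Measured compounds, each with its result in a functional assay on MCF7 cells (Homo sapiens) for antiproliferative activity, read by MTT assay, with a stated time of 48 h; on this read-out higher numbers stand for weaker inhibition and lower numbers for stronger inhibition:

compound 1 `Cc1ccccc1-n1nncc1CN1C(=O)C2(C(C#N)=C(N)Oc3c2c2nc4ccccc4nc2c2ccccc32)c2ccccc21` — > 50000 nM
compound 2 `Cc1cccc(-n2nncc2CN2C(=O)C3(C(C#N)=C(N)Oc4c3c3nc5ccccc5nc3c3ccccc43)c3ccccc32)c1` — > 50000 nM
compound 3 `N#CC1=C(N)Oc2c(c3nc4ccccc4nc3c3ccccc23)C12C(=O)N(Cc1cnnn1-c1ccc(Cl)cc1)c1ccccc12` — > 50000 nM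

All three share one core and differ only in the aryl group on the triazole nitrogen. Each result is a limit of the assay, not a number: compound 1 sits at > 50000 nM as a limit. Compound 2 likewise gives only a limit, > 50000 nM. Compound 3 too is known only as a limit, > 50000 nM, and the two other values shown are limits as well, so compound 3 cannot be placed relative to them. The steps a step that the two limits leave unreadable from compound 1 to compound 2, a step that the two limits leave unreadable from compound 1 to compound 3 and a step that the two limits leave unreadable from compound 2 to compound 3 are therefore unreadable in size; what unites them is the limit of > 50000 nM in this assay, at which 3 of the 3 values shown sit.

Compound 4 `N#CC1=C(N)Oc2c(c3nc4ccccc4nc3c3ccccc23)C12C(=O)N(Cc1cnnn1-c1cccc(Cl)c1)c1ccccc12` is the compound not yet measured. Its difference from compound 3 is 3-chlorophenyl in place of 4-chlorophenyl on an aromatic nitrogen. The closest comparison is the step from compound 2 to compound 3, which swaps one aryl for another and is unreadable because the limit of > 50000 nM in this assay, at which 3 of the 3 values shown sit, holds for both ends. With every measured aryl variant sitting at the limit, no direction can be drawn, and the expected step that the limit leaves unreadable from compound 3 to compound 4 is estimated as none beyond the scatter. Compound 4 is thus expected at about 60000 nM, most probably again as a limit, within 20000 nM to 200000 nM.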

Compound 4, half-maximal inhibitory concentration: 43600 nM
The estimate for compound 4 lay 1.4-fold (0.14 log units) above the measured number; the range from low to high includes it.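

In this assay, going by these compounds alone, compound 4 is the only one of the four compounds that gives a number rather than a limit, so 3-chlorophenyl in place of 4-chlorophenyl on the aromatic nitrogen does at least bring a value into the measurable range. The change itself gives an at least 1.1-fold lower number from compound 3 to compound 4 (0.05 log units; that floor lies within the scatter), while chloro in place of methyl gives an at least 1.1-fold lower number from compound 2 to compound 4 (0.05 log units; that floor lies within the scatter), and the wider aryl swap gives an at least 1.1-fold lower number from compound 1 to compound 4 (0.05 log units; that floor lies within the scatter). Each of these steps has only a floor, and those among compound 1, compound 2 and compound 3 cannot be read at all, because the other compounds stop at the assay's limit: the limit of > 50000 nM in this assay, at which 3 of the 4 values shown sit.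

Going by these compounds, how large the real gap between compound 3 and compound 4 is stays open. So does whether a 3-aminophenyl or a 3-carboxyphenyl on that nitrogen would give a clearly lower number.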